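Swapping the Carbonyl-Side Heteroaromatic Group in a Sulfonyl Benzylamide

The source may report more compounds than this note shows. Statements on the series, on what has been measured and on what is new or still open speak of the compounds shown alone.

Measured compounds:
compound 1, `O=C(NCc1ccc(S(=O)(=O)c2cc(F)cc(F)c2)cc1)c1cc2ccncc2o1`, 12%
compound 2, `O=C(NCc1ccc(S(=O)(=O)N2CCCCC2)cc1)c1cnc2nccn2c1`, 0.28%

Compound 1 and compound 2 were examined in an ADME assay on microsomes from liver (Mus musculus) for metabolic stability, read by LC-MS, with a stated time of 30 min, tested at 1 uM; a lower number here means that less of the compound is left, a higher number that more of the compound is left. Compound 1 gives 12%, and compound 2 gives 0.28%, the lower of the two numbers, with compound 1 standing higher by a gap that lies beyond the scatter of this assay.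

The next compound, compound 3 `O=C(NCc1ccc(S(=O)(=O)N2CCCCC2)cc1)c1cc2ccncc2o1`, keeps the sulfonyl side of compound 2 and changes the group on the carbonyl carbon: a group of 9 heavy atoms (7 carbon, 1 nitrogen, 1 oxygen; one five-membered aromatic ring with 1 hetero atom, one six-membered aromatic ring with 1 hetero atom) in place of a group of 9 heavy atoms (6 carbon, 3 nitrogen; one five-membered aromatic ring with 2 hetero atoms, one six-membered aromatic ring with 2 hetero atoms), on a carbonyl carbon. Among the compounds with values here, the entering group is the one that compound 1 carries on its carbonyl carbon, while the sulfonyl side of compound 3 is that of compound 2.

Within the data shown here, no measured pair shows this exact exchange alone, so its size is not known from the data. For compound 3 a step of a number 5.7 percentage points higher from compound 2 to compound 3 (within the scatter) is expected, upward and small, with the possibility that it stays within the scatter. Compound 3 is therefore estimated at 6%, in a range from 0.5% to 20%, because compound 1 with the same entering group gives 12%.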

Compound 3, percent of the compound remaining: 0.14%
For compound 3 the middle estimate is 5.9 percentage points above the measured one; the measured number lies below the stated range.
By their numbers in this assay, from the lowest: compounds 3 and 2 (each within the scatter of the next); then compound 1.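

With the sulfonyl side held, the exchange on the carbonyl carbon in this assay gives a number 0.1 percentage points lower from compound 2 to compound 3 (within the scatter), so in this pair the two carbonyl-side groups cannot be told apart and the low number of compound 2 is not lifted by the group that compound 1 carries. With the carbonyl-side group held, piperidin-1-yl in place of 3,5-difluorophenyl on a sulfonyl sulfur gives a number 11.9 percentage points lower from compound 1 to compound 3 (beyond the scatter), which places the one step beyond the scatter among these three compounds at the sulfonyl sulfur rather than at the carbonyl carbon. Nothing measured here offers a reason for either step.

As far as these compounds go, each place is covered by a single step, so it remains open whether the carbonyl-side exchange would also stay within the scatter with 3,5-difluorophenyl on the sulfonyl sulfur. From the compounds shown here alone, it is equally open how other groups on that sulfur, such as morpholin-4-yl or cyclohexyl, would stand against piperidin-1-yl and 3,5-difluorophenyl when the carbonyl-side group is held.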